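Notes on the methyl-thiophene analogue of the shared core

The source may hold more compounds than are shown below. What is called first, only, known or untested is meant among the compounds shown, and "the series" means these compounds.

Compound 3 `Cc1n[nH]cc1CN[C@@H]1C[C@H]2C[C@@H]([C@H]1C)C2(C)C` is known here only as a limit: in an ADME assay on MDCK cells (Canis lupus familiaris) for cytotoxicity, read by microscopy, with a stated time of 48 h (a higher number here means that more compound is tolerated, a lower number that less compound is tolerated), compound 3 gives > 100000 nM, which is a limit of the assay and not a number. Compound 2 `C[C@H]1[C@H](NCc2cnccn2)C[C@H]2C[C@@H]1C2(C)C` likewise stops at a limit, and in this assay compound 2 gives > 100000 nM. Among the measured compounds shown here, the single step that connects these two, a step that the two limits leave unreadable from compound 2 to compound 3, is therefore unreadable, since both values sit at the limit of > 100000 nM in this assay, at which 2 of the 3 values shown sit. For the measured compounds named here, compound 1 `C=C(C)c1csc(CN[C@@H]2C[C@H]3C[C@@H]([C@H]2C)C3(C)C)c1` is the only member with a number: in this assay compound 1 gives 25000 nM.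

Compound 4 `Cc1csc(CN[C@@H]2C[C@H]3C[C@@H]([C@H]2C)C3(C)C)c1` is still to be measured. The change from compound 3 is 4-methylthiophen-2-yl in place of 3-methyl-1H-pyrazol-4-yl on a saturated chain carbon bound to an amine nitrogen. No measured step carries this change, and the one step that is shown is unreadable, so it gives no size to lean on. Among the measured compounds compound 1 stands structurally nearest to compound 4, and compound 1 gives a number where compound 3 gives a limit; so compound 4 is expected to fall between the value of compound 1 and the limit, with a real chance that only a limit is again reported. Compound 4 is expected to give 50000 nM, with a range from 20000 nM to 100000 nM. The step this estimate means is expected to be an at least 2.0-fold lower number from compound 3 to compound 4 (0.30 log units; that floor lies within the scatter).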

Compound 4, minimum cytotoxic concentration: 12500 nM
Estimate against measurement, compound 4: 4.0-fold (0.60 log units) above, and the stated range ends above it.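

Among the compounds shown here, on a saturated chain carbon bound to an amine nitrogen, 4-methylthiophen-2-yl in place of 3-methyl-1H-pyrazol-4-yl gives an at least 8.0-fold lower number from compound 3 to compound 4 (0.90 log units; beyond the scatter), and 4-methylthiophen-2-yl in place of pyrazin-2-yl gives an at least 8.0-fold lower number from compound 2 to compound 4 (0.90 log units; beyond the scatter); these are the first steps at this place that can be read in this assay. Each of the two starts from a limit of the assay and not a number, so each size is only a floor: the limit of > 100000 nM in this assay, at which 2 of the 4 values shown sit. The change of methyl in place of 1-methylethenyl on an aromatic carbon reads as a 2.0-fold lower number from compound 1 to compound 4 (0.30 log units; within the scatter), so this pair gives no separation in this assay.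

It remains open whether the lower number in compound 4 goes with the sulfur-containing ring itself or with the absence of a hydrogen-bond donor in the group that enters, as the steps shown change both together. A phenyl ring or a furan-2-yl group at this place, and a carboxylic acid or a longer chain in place of the methyl on the aromatic carbon, would remain to be compared in the same read-out.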